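A few compounds are considered here, and "the series" means these few. Any claim that something is new, unique, unknown or untested is made for them only; others in the source may bear on it.

Measured compounds:
- compound 1 `Cn1c(-c2ccc(NC(=O)CCl)cc2)nc(-c2ccccc2)c1-c1ccccc1`: 3.4%
- compound 2 `Cn1cnnc1SCC(=O)Nc1ccc(-c2nc(-c3ccccc3)c(-c3ccccc3)n2C)cc1`: 33.1%
- compound 3 `Cn1nnnc1SCC(=O)Nc1ccc(-c2nc(-c3ccccc3)c(-c3ccccc3)n2C)cc1`: 21.9%

In a functional assay on MCF7 cells (Homo sapiens) for cytotoxicity, read by MTT assay, with a stated time of 24 h, tested at 0.64 ug/mL (a lower number here means a weaker effect, a higher number a stronger effect of the compound at the concentration tested), compound 2 gives the highest of the three numbers, with compound 3 nearest and compound 1 furthest. Compound 4 `CN(C)/C=C/N1CCN(CC(=O)Nc2ccc(-c3nc(-c4ccccc4)c(-c4ccccc4)n3C)cc2)CC1` has not been measured; it differs from compound 2 by 4-(2-(dimethylamino)ethenyl)piperazin-1-yl in place of (4-methyl-4H-1,2,4-triazol-3-yl)sulfanyl on a saturated chain carbon bound to a carbonyl carbon. Going by the values given here, no measured step covers this exchange. The nearest comparisons are a number 29.7 percentage points higher from compound 1 to compound 2 (beyond the scatter) and a number 18.5 percentage points higher from compound 1 to compound 3 (beyond the scatter), both showing that replacing the chloro at this position changed the number modestly, and a number 11.2 percentage points lower from compound 2 to compound 3 (beyond the scatter), a modest shift between two five-membered rings on the sulfur. The entering group is larger and of a different kind, so only a modest step is expected, most likely a small fall: a number 6.1 percentage points lower from compound 2 to compound 4 (within the scatter). Compound 4 is therefore estimated at 27%, within 10% to 48%.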

Compound 4, a percentage reported as activity, at one concentration (the size of the read-out at that concentration, not a potency): 1.2%
For compound 4 the middle estimate is 25.8 percentage points above the measured one, outside the stated range (below it).
By their numbers in this assay, from the lowest: compounds 4 and 1 (each within the scatter of the next); then compound 3; then compound 2.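

In this assay the gain seen with the two sulfanyl groups does not extend to every larger group on this saturated chain carbon bound to a carbonyl carbon: 4-(2-(dimethylamino)ethenyl)piperazin-1-yl gives a number 31.9 percentage points lower from compound 2 to compound 4 (beyond the scatter) and a number 20.7 percentage points lower from compound 3 to compound 4 (beyond the scatter) in the two direct comparisons. Set against chloro, the same group gives a number 2.2 percentage points lower from compound 1 to compound 4 (within the scatter) and so brings no gain over the simple starting group. Nothing available explains this difference. As far as these compounds go, it remains open whether the loss comes from the piperazine ring or its 2-(dimethylamino)ethenyl arm, and how an unsubstituted piperazine or a morpholine would behave here.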